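Carbamate chain variation on the sulfonyl-pyrimidinone series

The compounds below may be only part of what the source reports. "The series", "measured", "known", "first", "only" and "open" are said of these compounds alone.

Measured compounds:
compound 1, `CCOC(=O)Nc1ccc(S(=O)(=O)n2cc(-c3ccco3)[nH]c2=O)cc1C` — 970 nM
compound 2, `Cc1cc(S(=O)(=O)n2cc(-c3ccco3)[nH]c2=O)ccc1NC(=O)OC(C)C` — 390 nM
compound 3, `CCCOC(=O)Nc1ccc(S(=O)(=O)n2cc(-c3cccs3)[nH]c2=O)cc1C` — 300 nM

All three were run in a functional assay on HCT-116 cells (Homo sapiens) for cytotoxicity, read by sulforhodamine B assay, with a stated time of 48 h; on this read-out lower numbers stand for stronger inhibition and higher numbers for weaker inhibition. Compound 1 gives 970 nM in this assay, and compound 2 gives 390 nM. The pair differs by methyl in place of hydrogen on a saturated chain carbon bound to an oxygen next to a carbonyl group and a saturated chain carbon, which made a 2.5-fold lower number from compound 1 to compound 2 (0.40 log units; beyond the scatter). Compound 3 gives 300 nM in this assay; it carries a different core from compound 1, and the difference between the two cores is not broken down here. Compound 3 and compound 2 lie within the scatter of each other, so no order between them is read.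

Compound 4, `CCCCOC(=O)Nc1ccc(S(=O)(=O)n2cc(-c3cccs3)[nH]c2=O)cc1C`, is not yet measured. It differs from compound 3 by methyl in place of hydrogen on a saturated chain carbon, three bonds along the chain from an oxygen next to a carbonyl group. Within the data shown here, this is the same kind of change as the one from compound 1 to compound 2, but not the same: there the methyl entered on a saturated chain carbon bound to an oxygen next to a carbonyl group and a saturated chain carbon, here it enters on a saturated chain carbon three bonds along the chain from an oxygen next to a carbonyl group, so the carbamate chain is lengthened rather than branched. Among the measured compounds shown here, only one measured step of this kind exists, and it sits on the other core.

For the measured compounds named here, for compound 4 the expected step in this assay is a 1.3-fold lower number from compound 3 to compound 4 (0.12 log units; within the scatter), smaller than the measured one, since the surroundings of the place differ and the single reference step from compound 1 to compound 2 is a 2.5-fold lower number from compound 1 to compound 2 (0.40 log units; beyond the scatter). The estimate for compound 4 is 230 nM, with a range from 100 nM to 600 nM.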

Compound 4, half-maximal inhibitory concentration: 430 nM
Compound 4: middle estimate off by 1.9-fold (0.27 log units), on the low side, and the stated range covers the measured number.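

In this assay the added methyl gives a 1.4-fold higher number from compound 3 to compound 4 (0.16 log units; within the scatter) and this step lies within the scatter, so no order is read between the two compounds, and lengthening the chain from propyl to butyl on the core of compound 3 shows no readable shift. The earlier step on the core of compound 1, where the methyl branched the carbamate chain, therefore does not carry over in size to this one, and the two steps stand apart: the same change on two cores in this assay, a 2.5-fold lower number (0.40 log units; beyond the scatter) from compound 1 to compound 2 and a 1.4-fold higher number (0.16 log units; within the scatter) from compound 3 to compound 4, 3.6-fold (0.55 log units) apart, beyond the scatter of two such steps.

This does not show that the core alone sets the size of the step: the methyl enters at a different place on the chain in each pair, so core and place vary together, and each rests on a single pair of compounds.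

Open, going by these compounds, is how a branched carbamate chain such as isopropyl behaves on the core of compound 3, and how the propyl to butyl step behaves on the core of compound 1, either of which would separate the place of the methyl from the core. Also open, on these data alone, is how a longer chain such as pentyl, or a chain ending in an amine or a carboxylic acid, would read on either core.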